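The source may report more compounds than this note shows. Statements on the series, on what has been measured and on what is new or still open speak of the compounds shown alone.

Compound 1 `COc1cccc(Nc2nc(Nc3cc(C)[nH]n3)cc(N3CCN(C)CC3)n2)c1`: 332 nM
Compound 2 `Cc1cc(Nc2cc(N3CCN(C)CC3)nc(Nc3ccc(C#N)cc3)n2)n[nH]1`: 140 nM

Both values come from a functional assay on A-431 cells (Homo sapiens) for antiproliferative activity, read by CCK-8 assay, with a stated time of 72 h; on this read-out higher numbers stand for weaker inhibition and lower numbers for stronger inhibition. Compound 2 has the lowest of the two numbers, which makes it the stronger inhibitor of this pair. The next compound, compound 3 `COc1ccc(Nc2nc(Nc3cc(C)[nH]n3)cc(N3CCN(C)CC3)n2)cc1`, carries methoxy in place of cyano on an aromatic carbon, para to a large group (methoxy in place of cyano on an aromatic carbon).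

Within the data shown here, only one measured step bears on this change: a 2.4-fold lower number from compound 1 to compound 2 (0.38 log units; beyond the scatter). That modest step swapped 3-methoxyphenyl for 4-cyanophenyl, so it changed both the group and its place, and the data cannot separate the two. Compound 3 keeps the place used in compound 2 but has the methoxy group of compound 1, which gives 332 nM. A modest rise of similar size is therefore expected, an estimated 1.9-fold higher number from compound 2 to compound 3 (0.29 log units; within the scatter). The estimate for compound 3 is 270 nM, with an expected range from 100 nM to 700 nM.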

Compound 3, half-maximal inhibitory concentration: 385 nM
Estimate against measurement, compound 3: 1.4-fold (0.15 log units) below; measured number inside the range.
By their numbers in this assay, from the lowest: compound 2; then compounds 1 and 3 (each within the scatter of the next).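

With the place held fixed, the group can now be read alone: in this assay, replacing cyano with methoxy at the aromatic carbon para to a large group gives a 2.8-fold higher number from compound 2 to compound 3 (0.44 log units; beyond the scatter). Moving the methoxy group, by contrast, from 3-methoxyphenyl to 4-methoxyphenyl gives a 1.2-fold higher number from compound 1 to compound 3 (0.06 log units; within the scatter), so among these compounds the difference follows the change from methoxy to cyano rather than the change of place. No available measurement explains why these groups differ.

The compounds shown leave open whether the cyano group would keep its lower number if moved in the same way as the methoxy group. They also leave open how an amine, a carboxylic acid or a fluorine atom at this place would compare.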